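Amino for hydrogen on two related cores: cytotoxicity notes

The source may hold more compounds than are shown below. What is called first, only, known or untested is meant among the compounds shown, and "the series" means these compounds.

Measured compounds:
compound 1 `ClCc1ccc(Cn2cnc3c(Cl)ncnc32)cc1`: 5120 nM
compound 2 `Nc1nc(Cl)c2ncn(Cc3ccc(CCl)cc3)c2n1`: 75900 nM
compound 3 `ClCc1ccccc1Cn1cnc2c(Cl)ncnc21`: 7410 nM

All three were tested in a functional assay on HCC 2998 cells (Homo sapiens) for cytotoxicity, read by sulforhodamine B assay, with a stated time of 48 h; on this read-out higher numbers stand for lower toxicity in this test and lower numbers for higher toxicity in this test. Compound 1 and compound 2 differ by one change, (amino in place of hydrogen on an aromatic carbon), and that change gave a 15-fold higher number from compound 1 to compound 2 (1.17 log units; beyond the scatter). Compound 3 has the same atoms as compound 1 joined differently; the difference between the two cores is not broken down here. Compound 3 and compound 1 lie within the scatter of each other in this assay, so no order between them is claimed.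

Compound 4 `Nc1nc(Cl)c2ncn(Cc3ccccc3CCl)c2n1` has not yet been measured. It differs from compound 3 by amino in place of hydrogen on an aromatic carbon, the same change as from compound 1 to compound 2, since the place descriptions match word for word. On this one precedent, and because compound 1 to compound 2 gave a 15-fold higher number from compound 1 to compound 2 (1.17 log units; beyond the scatter), a step of similar size is expected from compound 3 to compound 4, an 11-fold higher number from compound 3 to compound 4 (1.03 log units; beyond the scatter). With compound 3 at 7410 nM as the starting point, compound 4 is estimated at 80000 nM, between 25000 nM and 250000 nM.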

Compound 4, concentration lethal to 50% of the cells: 26300 nM
Estimate against measurement, compound 4: 3.0-fold (0.48 log units) above; the range from low to high includes it.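

In this assay, amino in place of hydrogen on an aromatic carbon raises the number on the second core as well (a 3.5-fold higher number from compound 3 to compound 4 (0.55 log units; beyond the scatter)), so the direction of the step carries from the core of compound 1 to the core of compound 3. The size does not carry: the same change on two cores in this assay, a 15-fold higher number (1.17 log units; beyond the scatter) from compound 1 to compound 2 and a 3.5-fold higher number (0.55 log units; beyond the scatter) from compound 3 to compound 4, 4.2-fold (0.62 log units) apart, beyond the scatter of two such steps. These two cores show only that the direction held twice, they give no size to expect on a further core, and they do not explain the gap between the steps.

Open, on these data alone, is whether a dimethylamino or hydroxyl group on that aromatic carbon would shift the number as amino does. Also open, as far as these compounds go, is whether the step would persist with a methoxy group in place of the chloro group.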